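The source may hold more compounds than are shown below. What is called first, only, known or untested is meant among the compounds shown, and "the series" means these compounds.

Compound 1 `COc1ccc(Nc2nc3c(c(Oc4cccc(NC(=O)C=C(C)C)c4)n2)CSCC3)cc1`: > 50000 nM (a limit)
Compound 2 `C/C=C/C(=O)Nc1cccc(Oc2nc(Nc3ccc(OC)nc3)nc3c2CSCC3)c1`: 21100 nM

Both compounds were tested in a functional assay on MCF7 cells (Homo sapiens) for antiproliferative activity, read by MTT assay, with a stated time of 72 h; on this read-out lower numbers stand for stronger inhibition and higher numbers for weaker inhibition. Among the measured compounds shown here, compound 2 gives 21100 nM, the only actual number so far, so it can be ranked against no other measured value. Compound 1 gives > 50000 nM, which is a limit of this assay and not a number.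

The next compound to be tested is compound 3 `COc1ccc(Nc2nc3c(c(Oc4cccc(NC(=O)C=C(C)C)c4)n2)CSCC3)cn1`. It departs from compound 2 on a carbonyl carbon, where 2-methylprop-1-en-1-yl stands in place of prop-1-en-1-yl: 2-methylprop-1-en-1-yl in place of prop-1-en-1-yl on a carbonyl carbon. For the measured compounds named here, no measured pair isolates this change, so any forecast is tentative. Going by the values given here, the only guide is compound 1, which also carries 2-methylprop-1-en-1-yl and gives > 50000 nM, a limit. On that slim basis, a small move toward weaker inhibition seems more likely than a move toward stronger inhibition, and it may stay within the usual scatter. The expected change is a 1.4-fold higher number from compound 2 to compound 3 (0.15 log units; within the scatter). A result reported only as a limit would also be no surprise. For compound 3 the estimated value is 30000 nM, with an expected range from 12000 nM to 65000 nM.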

Compound 3, half-maximal inhibitory concentration: 22200 nM
Compound 3: the middle estimate sits 1.4-fold (0.13 log units) above what was measured; the measured number falls inside the stated range.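

In this assay, the change to 2-methylprop-1-en-1-yl in place of prop-1-en-1-yl on a carbonyl carbon now has a measured pair, and it gives a 1.1-fold higher number from compound 2 to compound 3 (0.02 log units; within the scatter), so this pair does not tell the two groups apart. Among the compounds shown here, the other change, 6-methoxypyridin-3-yl in place of 4-methoxyphenyl on a nitrogen on an aromatic ring, can also now be read for the first time, as an at least 2.2-fold lower number from compound 1 to compound 3 (0.35 log units; beyond the scatter), which shows that with 2-methylprop-1-en-1-yl held constant, the group on that nitrogen makes a difference beyond the scatter. The value of compound 1 is a limit and not a number, so this step gives only a minimum size: the limit of > 50000 nM in this assay, at which 1 of the 3 values shown sits.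

The compounds shown leave open whether a saturated propyl chain or a chain carrying a dimethylamino group on the carbonyl carbon would also read like these two groups. They also leave open whether 4-methoxyphenyl would give a similar step when paired with prop-1-en-1-yl, and how far an unsubstituted phenyl or a chlorophenyl on that nitrogen would differ from 6-methoxypyridin-3-yl.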